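The source may hold more compounds than are shown below. What is called first, only, known or untested is meant among the compounds shown, and "the series" means these compounds.

Compound 1 `Cc1ccc(NC(=O)Nc2nc(-c3cc4ccccc4o3)cs2)cc1`: 500 nM
Compound 2 `O=C(Nc1ccc([N+](=O)[O-])cc1)Nc1nc(-c2cc3cc(Br)ccc3o2)cs1`: > 200000 nM
Compound 3 `COc1ccc(NC(=O)Nc2nc(-c3cc4cc(Br)ccc4o3)cs2)cc1`: > 200000 nM

Going by the values given here, in a physicochemical assay, with a stated time of 6 min (on this read-out lower numbers stand for stronger inhibition and higher numbers for weaker inhibition), compound 1 gives 500 nM, and this is the only plain number among the three measured compounds. Compound 2 reaches only a limit of the assay, > 200000 nM. Compound 3 likewise reaches only a limit, > 200000 nM. Among the compounds with values here, the single step between measured compounds that differ in one place, a step that the two limits leave unreadable from compound 2 to compound 3, therefore cannot be sized, so it gives no reading on the effect of a methoxy group.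

Compound 4 `COc1cccc(NC(=O)Nc2nc(-c3cc4ccccc4o3)cs2)c1` differs from compound 1 in one place: 3-methoxyphenyl in place of 4-methylphenyl on an amide-type nitrogen. Within the data shown here, no measured step concerns a 3-methoxyphenyl on this nitrogen, and the one step that touches a methoxy group is unreadable, as the limit of > 200000 nM in this assay, at which 2 of the 3 values shown sit, shows. With no readable step to lean on, no shift beyond the usual scatter is expected, and the estimate carries a wide range. Compound 4 is therefore estimated at 700 nM in this assay, between 150 nM and 4000 nM, which means an expected step of a 1.4-fold higher number from compound 1 to compound 4 (0.15 log units; within the scatter).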

Compound 4, half-maximal inhibitory concentration: 200 nM
The estimate for compound 4 lay 3.5-fold (0.54 log units) above the measured number; the measured number falls inside the stated range.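

Going by these compounds alone, changing the group on this amide-type nitrogen gives the only readable step so far in this assay, with a 2.5-fold lower number from compound 1 to compound 4 (0.40 log units; beyond the scatter). The number therefore responds to this group, and 3-methoxyphenyl is accepted here in place of 4-methylphenyl with a modest gain rather than a loss of inhibition. The two groups differ in more than one respect, as 3-methoxyphenyl carries an oxygen and a hydrogen-bond acceptor that 4-methylphenyl lacks, and nothing shown gives a measured reason for the step.

As far as these compounds go, whether 3-methylphenyl would give a similar number stays open, and such a comparison would help separate the part played by the oxygen from that played by the group's place on the ring. Also open, from the compounds shown here alone, is how this nitrogen would accept a phenyl ring carrying a carboxylic acid or an amine.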